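A few compounds are considered here, and "the series" means these few. Any claim that something is new, unique, unknown or untested is made for them only; others in the source may bear on it.

Within the data shown here, compound 2 `CC1=CC[C@H](C(C)(C)NC(=S)N/N=C/c2ccccc2O)CC1` gives the lowest number so far in a functional assay on NCI-H460 cells (Homo sapiens) for inhibition, read by sulforhodamine B assay, with a stated time of 48 h (a lower number here means a stronger inhibitor of growth, a higher number a weaker inhibitor of growth), namely 8400 nM. Among the measured compounds shown here, its only neighbour is compound 1 `COc1ccc(/C=N/NC(=S)NC(C)(C)[C@H]2CC=C(C)CC2)cc1`, which in this assay gives 47800 nM; the step of a 5.7-fold lower number from compound 1 to compound 2 (0.76 log units; beyond the scatter) is the one measured change of the group on the carbon with a double bond to nitrogen. Compound 3 `CC1=CC[C@H](C(C)(C)NC(=S)N/N=C/c2ccc(F)cc2)CC1` is not yet measured. Its difference from compound 2 is 4-fluorophenyl in place of 2-hydroxyphenyl on a carbon with a double bond to nitrogen. For the measured compounds named here, the one step that bears on it, a 5.7-fold lower number from compound 1 to compound 2 (0.76 log units; beyond the scatter), shows that exchanging a 2-hydroxyphenyl for a 4-methoxyphenyl at this carbon moved the number well beyond the scatter, towards weaker growth inhibition. Since compound 3 likewise loses the 2-hydroxyphenyl, compound 3 is expected to show a step of a 3.6-fold higher number from compound 2 to compound 3 (0.55 log units; beyond the scatter) in this assay, a higher number. Compound 3 is therefore estimated at 30000 nM, with a range from 10000 nM to 90000 nM.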

Compound 3, concentration for total growth inhibition: > 100000 nM
Compound 3 gave a limit, no number (the forecaster's own chance of this, stated with the estimate: 5%); middle value at least 3.3-fold (0.52 log units) from the limit.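

In this assay, compound 3 yields a limit of the assay and not a number: the limit of > 100000 nM in this assay, at which 1 of the 3 values shown sits.

Even so, the step of an at least 11-fold higher number from compound 2 to compound 3 (1.07 log units; beyond the scatter) is larger than the earlier step at this carbon, a 5.7-fold lower number from compound 1 to compound 2 (0.76 log units; beyond the scatter), so replacing the 2-hydroxyphenyl costs more here than the first pair alone showed. The step of an at least 2.0-fold higher number from compound 1 to compound 3 (0.32 log units; beyond the scatter) adds that the two groups lacking the hydroxy group are not equivalent either, with the 4-fluorophenyl giving the weaker growth inhibition of the two, so the three groups on the carbon with a double bond to nitrogen fall into a clear order.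

The compounds shown leave open whether this order follows the hydroxy group itself, and how an unsubstituted phenyl or a 2-aminophenyl would read at this carbon. As far as these compounds go, how far compound 3 actually lies past its limit also stays unknown.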